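Replacing furan-2-yl with ethynyl on compound 3

A few compounds are considered here, and "the series" means these few. Any claim that something is new, unique, unknown or untested is made for them only; others in the source may bear on it.

Of the compounds shown here, three have been measured in an ADME assay on BJ cells (Homo sapiens), read by MTT assay, with a stated time of 72 h; on this read-out lower numbers stand for stronger inhibition and higher numbers for weaker inhibition. Compound 1 `COc1ncnc2c1c(-c1ccccc1)cn2[C@@H]1O[C@H](CO)[C@@H](O)[C@H]1O` reached only a limit of the assay, > 100000 nM. Compound 2 `CSc1ncnc2c1c(-c1ccsc1)cn2[C@@H]1O[C@H](CO)[C@@H](O)[C@H]1O` gives 95800 nM. Compound 3 `CNc1ncnc2c1c(-c1ccco1)cn2[C@@H]1O[C@H](CO)[C@@H](O)[C@H]1O` gives 5040 nM, the lower of the two true numbers, and the gap between them lies beyond the usual scatter. Compound 4 `C#Cc1cn([C@@H]2O[C@H](CO)[C@@H](O)[C@H]2O)c2ncnc(NC)c12` has ethynyl in place of furan-2-yl on an aromatic carbon. Among the measured compounds shown here, no measured pair shows this swap, so the expectation in this assay is loose: a modest move towards a lower number, which may not clear the scatter. The expected change is a 2.0-fold lower number from compound 3 to compound 4 (0.30 log units; within the scatter). For compound 4, the estimate is 2500 nM, with an expected range of 250 nM to 25000 nM.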

Compound 4, half-maximal inhibitory concentration: 86000 nM
Beside the measured number, compound 4's estimate is 34-fold (1.54 log units) below it; the measured number lies above the stated range.
By their numbers in this assay, from the lowest: compound 3; then compounds 4 and 2 (each within the scatter of the next). At a limit, above all of these: compound 1.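

Compared in a single place, a 17-fold higher number from compound 3 to compound 4 (1.23 log units; beyond the scatter) in this assay, so replacing furan-2-yl with ethynyl on this aromatic carbon clearly weakens inhibition. The earlier compounds shown here differ in more than one place and could not show that this group alone moves the number so far. Compound 4 also leaves little room on the read-out for any further rise: the limit of > 100000 nM in this assay, at which 1 of the 4 values shown sits.

A single swap cannot separate the loss of the ring from the loss of its oxygen. From the compounds shown here alone, whether an ethyl chain or an amine on this carbon would land nearer compound 3 or compound 4 remains open.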